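A few compounds are considered here, and "the series" means these few. Any claim that something is new, unique, unknown or untested is made for them only; others in the source may bear on it.

Measured compounds:
compound 1 `COc1ccc(-c2cc(/C=C/C(=O)c3ccc(N)cc3)[nH]n2)cc1`, 94%
compound 2 `COc1cc(-c2cc(/C=C/C(=O)c3ccc(Cl)c(Cl)c3)[nH]n2)cc(OC)c1OC`, 96%

In a functional assay on SN12C cells (Homo sapiens) for cytotoxicity, read by sulforhodamine B assay, with a stated time of 48 h, tested at 0.1 uM (on this read-out higher numbers stand for a weaker effect at the one concentration tested and lower numbers for a stronger effect), compound 2 gives 96%. Within the data shown here, the only other measured compound, compound 1, gives 94% in this assay, and the two numbers lie within the usual scatter of each other, so neither stands apart. Both numbers sit close to the full value, meaning that at this single concentration the cells are barely affected by either compound.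

Compound 3 `COc1ccc(C(=O)/C=C/c2cc(-c3cc(OC)c(OC)c(OC)c3)n[nH]2)cc1` has not yet been measured. It differs from compound 2 in one place: 4-methoxyphenyl in place of 3,4-dichlorophenyl on a carbonyl carbon. Among the measured compounds shown here, no step between measured compounds shows what such a swap does on this read-out. Because compound 2 gives 96% and compound 1 gives 94%, both near the top, the expected step of a number 1 percentage points lower from compound 2 to compound 3 (within the scatter) is none beyond the scatter. For compound 3 the estimate in this assay is 95%, with a range from 85% to 103%.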

Compound 3, a percentage reported as activity, at one concentration (the size of the read-out at that concentration, not a potency): 96%
Compound 3: the middle estimate sits 1 percentage points below what was measured; low and high end bracket the measured number.
By their numbers in this assay, from the lowest: compounds 1, 2 and 3 (each within the scatter of the next).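

Among these compounds, this is the first pair that differs in one place only, so the swap of 3,4-dichlorophenyl for 4-methoxyphenyl on a carbonyl carbon can now be read directly: this assay shows no change at the digits printed from compound 2 to compound 3 (within the scatter). The group that enters carries a hydrogen-bond acceptor and the group that leaves carries none, yet the read-out does not separate them, and with both compounds close to the full value, neither group brings a clear effect on the cells at this concentration. Nothing available explains this flat result.

From the compounds shown here alone, whether a carboxylic acid or a nitrile on this aromatic ring would lower the number remains open. Also open, going by these compounds, is whether compound 2 and compound 3 would separate at a higher concentration, where the cells might respond.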